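The source may report more compounds than this note shows. Statements on the series, on what has been measured and on what is new or still open speak of the compounds shown alone.

In an ADME assay on TZM-b1 cells (Homo sapiens) for cytotoxicity, read by XTT assay, with a stated time of 3 days (on this read-out lower numbers stand for higher toxicity in this test and higher numbers for lower toxicity in this test), compound 1 `Cc1ccc(NC(=O)C(=O)NC(c2nc(C)c(CCO)s2)C2CCCCN2)c(F)c1` stands only at a limit, not at a number, and compound 1 gives > 78800 nM. Compound 2 `Cc1ccc(NC(=O)C(=O)NC(c2nc(C)c(CO)s2)C2CCCCN2)c(F)c1` is also reported only as a limit, and compound 2 gives > 88000 nM. Compound 3 `Cc1nc(C(NC(=O)C(=O)Nc2ccc(Cl)cc2)C2CCCNC2)sc1CCO` is the only one of the three with a true number, and compound 3 gives 59400 nM.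

Compound 4 `Cc1nc(C(NC(=O)C(=O)Nc2ccc(F)c(F)c2)C2CCCCN2)sc1CCO` keeps the core of compound 1 and exchanges one group: 3,4-difluorophenyl in place of 2-fluoro-4-methylphenyl on an amide-type nitrogen. Put simply, it has 3,4-difluorophenyl in place of 2-fluoro-4-methylphenyl on an amide-type nitrogen. Among the compounds with values here, the one measured step, a step that the two limits leave unreadable from compound 1 to compound 2, has no readable size and concerns a different part of the molecule, so no measured step bears directly on this exchange. Within the data shown here, the expectation therefore leans on compound 3, the one compound with a measured number and a different group on the amide-type nitrogen, at 59400 nM. No change beyond the usual scatter is expected in this assay, and no direction can be favoured. The expected size is an at least 1.1-fold lower number from compound 1 to compound 4 (0.05 log units; that floor lies within the scatter), which is only an estimate. For compound 4 the estimated value is 70000 nM, with an expected range of 35000 nM to 130000 nM.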

Compound 4, half-maximal cytotoxic concentration: > 78200 nM
Compound 4 gave a limit, no number; the forecaster's own chance of this, stated with the estimate: 50%; middle value at least 1.1-fold (0.04 log units) away from the limit.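

In this assay compound 4 gives > 78200 nM, which is a limit and not a number. Within the data shown here, compound 1 also gives only a limit, > 78800 nM, so no step from compound 1 to compound 4 can be read. The compounds shown leave open whether exchanging 2-fluoro-4-methylphenyl for 3,4-difluorophenyl on the amide-type nitrogen changes the read-out at all.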